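The source may hold more compounds than are shown below. What is called first, only, known or untested is meant among the compounds shown, and "the series" means these compounds.

Compound 2 `Oc1cccc(-c2cc(-c3ccc(F)cc3)cc(-c3cccc(O)c3)n2)c1` carries two 3-hydroxyphenyl groups on the shared core, and in a functional assay on HCT-15 cells (Homo sapiens) for inhibition (on this read-out lower numbers stand for stronger inhibition and higher numbers for weaker inhibition), compound 2 gives 6310 nM. Among the values shown, compound 2 is the only one that is a number; the other entry is a limit. Compound 1 `Oc1cccc(-c2cc(-c3ccc(F)cc3)cc(-c3ccccc3O)n2)c1` differs from compound 2 in bearing a 2-hydroxyphenyl in place of one 3-hydroxyphenyl. In this assay compound 1 gives > 50000 nM, which is a limit of the assay and not a number (the limit of > 50000 nM in this assay, at which 1 of the 2 values shown sits). Among the compounds with values here, the one measured step, an at least 7.9-fold lower number from compound 1 to compound 2 (0.89 log units; beyond the scatter), concerns only the hydroxyphenyl pattern.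

Compound 3 `Oc1cccc(-c2cc(-c3ccccc3C(F)(F)F)cc(-c3cccc(O)c3)n2)c1` is not yet measured. Its difference from compound 2 is 2-(trifluoromethyl)phenyl in place of 4-fluorophenyl on an aromatic carbon. Within the data shown here, no measured step touches the group on the aromatic carbon opposite the ring nitrogen, so the step from compound 2 to compound 3 has no precedent, and the hydroxyphenyl step cannot be carried over to it. The expected step in this assay is a 1.0-fold lower number from compound 2 to compound 3 (0.00 log units; within the scatter), with no direction beyond the scatter and a wide range. Compound 3 is therefore estimated at 6300 nM, within 1500 nM to 30000 nM.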

Compound 3, half-maximal inhibitory concentration: 8150 nM
Beside the measured number, compound 3's estimate is 1.3-fold (0.11 log units) below it; the measured number falls inside the stated range.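

In this assay the group on the aromatic carbon opposite the ring nitrogen now has its first measured step, and that step is a 1.3-fold higher number from compound 2 to compound 3 (0.11 log units; within the scatter) for 2-(trifluoromethyl)phenyl in place of 4-fluorophenyl. The entering group has 10 heavy atoms against 7 in the group that leaves, yet the two compounds cannot be told apart on this read-out, whereas the step in the hydroxyphenyl pattern lies beyond the scatter. Nothing at hand gives a reason for how little this exchange registers.

On these data alone, this single step swaps the identity of the substituent and where it sits on the phenyl ring in one move, so the contribution of each remains open, as does whether 2-(trifluoromethyl)phenyl would behave the same way with a 2-hydroxyphenyl group on the core. Also open is whether this position tolerates anything other than a substituted phenyl, such as an amine, a carboxylic acid or a longer alkyl chain, since the compounds shown hold only these two aromatic groups there.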